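Benzothiazole-aryl enaminone series: effect of removing a methyl

The source may hold more compounds than are shown below. What is called first, only, known or untested is meant among the compounds shown, and "the series" means these compounds.

Measured so far in a functional assay on HeLa cells (Homo sapiens) for antiproliferative activity, read by sulforhodamine B assay, with a stated time of 48 h; a higher number here means a weaker inhibitor, a lower number a stronger inhibitor:
compound 1 `COc1cc(C(=O)/C=C\Nc2ccc(-c3nc4cc(OC)c(OC)c(OC)c4s3)cc2)c(Br)c(OC)c1OC` gives 6600 nM
compound 2 `COc1cc(OC)c2sc(-c3ccc(N/C=C\C(=O)c4ccc(OC)c(F)c4)c(C)c3)nc2c1` gives 14700 nM
compound 3 `COc1cc(OC)c2sc(-c3ccc(N/C=C\C(=O)c4ccc(OC)c([N+](=O)[O-])c4)c(C)c3)nc2c1` gives 9390 nM

Compound 2 stands highest of the three numbers in this assay; compound 3 is nearest, compound 1 furthest. Among the compounds with values here, the only single-point step, a 1.6-fold lower number from compound 2 to compound 3 (0.19 log units; within the scatter), changes the other aromatic ring and is within the scatter. Compound 4 `COc1cc(OC)c2sc(-c3ccc(N/C=C\C(=O)c4ccc(OC)c(F)c4)cc3)nc2c1` differs from compound 2 by hydrogen in place of methyl on an aromatic carbon. Within the data shown here, no measured pair isolates this change; compound 1 lacks the methyl but differs elsewhere as well, so its value cannot be read as a step. Among the measured compounds shown here, with no directly bearing step, no shift beyond the scatter is expected. Compound 4 is therefore estimated at 12000 nM (range 5000 nM to 30000 nM), the expected step being a 1.2-fold lower number from compound 2 to compound 4 (0.09 log units; within the scatter).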

Compound 4, half-maximal inhibitory concentration: 7300 nM
Beside the measured number, compound 4's estimate is 1.6-fold (0.22 log units) above it, within the range that was stated.
By their numbers in this assay, from the lowest: compounds 1, 4, 3 and 2 (each within the scatter of the next, the first and the last beyond it).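

In this assay, hydrogen in place of methyl on this aromatic carbon gives a 2.0-fold lower number from compound 2 to compound 4 (0.30 log units; within the scatter), the first step read at this position. With fluoro on the other aromatic ring, removing the methyl therefore produces no shift beyond the scatter. Nothing on hand offers an explanation for this step. Open, from the compounds shown here alone, is whether an amine, a methoxy group or a longer chain on this carbon would move the number beyond the scatter. Also open, going by these compounds, is whether the same step holds with nitro in place of fluoro.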